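Swapping an isopropyl amide for a benzamide

A few compounds are considered here, and "the series" means these few. Any claim that something is new, unique, unknown or untested is made for them only; others in the source may bear on it.

Of the compounds shown here, three sharing one core have been tested in an assay on LtK cells with ATP-sensitive inward rectifier potassium channel 11 (Homo sapiens) as the target; on this read-out lower numbers stand for an effect already at smaller amounts and higher numbers for an effect only at larger amounts of compound. Compound 1, `CC(C)C(=O)Nc1c(C(O)(C(F)(F)F)C(F)(F)F)ccc2ccccc12`, carries an isopropyl group on the amide carbonyl and gives 6630 nM, the highest of the three numbers. Compound 2, `CCC(CC)C(=O)Nc1c(C(O)(C(F)(F)F)C(F)(F)F)ccc2ccccc12`, has a pentan-3-yl group there and gives 4340 nM; the step of a 1.5-fold lower number from compound 1 to compound 2 (0.18 log units; within the scatter) is a change in words only, not in substance. Compound 3, `COCC(=O)Nc1c(C(O)(C(F)(F)F)C(F)(F)F)ccc2ccccc12`, carries a methoxymethyl group and gives 213 nM, so that the step of a 31-fold lower number from compound 1 to compound 3 (1.49 log units; beyond the scatter) is a large one.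

The unmeasured compound 4 is `O=C(Nc1c(C(O)(C(F)(F)F)C(F)(F)F)ccc2ccccc12)c1ccccc1`. Compared with compound 1 the difference is phenyl in place of isopropyl on a carbonyl carbon. Neither measured step covers an aromatic ring at this position. The step from compound 1 to compound 2 shows that a larger alkyl group hardly moves the number, while the step from compound 1 to compound 3 shows that this position can shift the number strongly. A phenyl group shares nothing counted with methoxymethyl, so the expectation for compound 4 leans toward a small change and carries wide uncertainty: an estimated 1.9-fold lower number from compound 1 to compound 4 (0.28 log units; within the scatter). In this assay compound 4 is therefore expected to give about 3500 nM, most plausibly between 800 nM and 15000 nM.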

Compound 4, half-maximal effective concentration: 44 nM
Compound 4: middle estimate off by 80-fold (1.90 log units), on the high side; the measured number lies below the stated range.
By their numbers in this assay, from the lowest: compound 4; then compound 3; then compounds 2 and 1 (each within the scatter of the next).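

In this assay, the position on the carbonyl carbon proves far more responsive than the alkyl groups suggested: phenyl in place of isopropyl brings a 150-fold lower number from compound 1 to compound 4 (2.18 log units; beyond the scatter) and phenyl in place of pentan-3-yl brings a 99-fold lower number from compound 2 to compound 4 (1.99 log units; beyond the scatter), so a change of group here can matter far more than the step between those two alkyl groups implied. Methoxymethyl had given the lowest number so far, yet phenyl goes further still, with a 4.8-fold lower number from compound 3 to compound 4 (0.68 log units; beyond the scatter) as a modest step that nevertheless lies beyond the scatter, which makes an aromatic ring of carbon the best of the four groups on this read-out. Nothing measured alongside these numbers bears on why phenyl has this effect.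

The compounds shown cannot separate the aromatic ring from the six carbons it contains, and a cyclohexyl group on the same carbonyl carbon would put that question directly. Also open, going by these compounds, is whether the low number survives when a pyridyl ring replaces the phenyl ring, or when the phenyl ring itself carries a further group such as a methoxy group or a nitrile.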